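The source may report more compounds than this note shows. Statements on the series, on what has been measured and on what is new or still open speak of the compounds shown alone.

Compound 1 `CC(=O)N[C@@H]1CCC[C@H](C(=O)Nc2cc(-c3cnn(C)c3C)c(Cl)cn2)C1` has the lowest number of the three compounds measured in an ADME assay on cells (Hepatocyte, Rattus norvegicus) for metabolic stability, using equilibrium dialysis; a higher number here means faster removal of the compound, a lower number slower removal: compound 1 gives 10 uL/min. Compound 2 `CC(=O)N[C@@H]1CCC[C@H](C(=O)Nc2cc(-c3cnn4c3CCC4)c(Cl)cn2)C1` gives 72 uL/min in this assay, and compound 3 `CC(=O)N[C@@H]1CCC[C@H](C(=O)Nc2cc(-c3cnn4c3CCCCC4)c(Cl)cn2)C1` gives 51 uL/min. Both steps away from compound 1 were beyond the scatter: a 7.2-fold higher number from compound 1 to compound 2 (0.86 log units; beyond the scatter) and a 5.1-fold higher number from compound 1 to compound 3 (0.71 log units; beyond the scatter). Compound 4 `CC(=O)N[C@@H]1CCC[C@H](C(=O)Nc2cc(-c3cnn4c3CN(C)CC4)c(Cl)cn2)C1` is not yet measured. It differs from compound 1 by a group of 10 heavy atoms (7 carbon, 3 nitrogen; one five-membered aromatic ring with 2 hetero atoms, one six-membered non-aromatic ring with 2 hetero atoms) in place of a group of 7 heavy atoms (5 carbon, 2 nitrogen; one five-membered aromatic ring with 2 hetero atoms), on an aromatic carbon. This change resembles the two measured steps, in that the 1,5-dimethyl-1H-pyrazol-4-yl group is again replaced by a larger fused bicyclic group on the same aromatic carbon, here with a six-membered non-aromatic ring carrying 2 hetero atoms. Both measured steps of this type gave a modest rise in this assay, so a rise of similar size is expected for compound 4, and the outcome of compound 2 and compound 3 leaves the exact size uncertain. The estimated step is a 4.5-fold higher number from compound 1 to compound 4 (0.65 log units; beyond the scatter). Compound 4 is thus expected to give about 45 uL/min in this assay, within a range from 15 uL/min to 130 uL/min.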

Compound 4, intrinsic clearance in a liver preparation (reported as CLH), per the amount of preparation that the assay uses: 7.7 uL/min
Beside the measured number, compound 4's estimate is 5.8-fold (0.77 log units) above it, outside the stated range (below it).
By their numbers in this assay, from the lowest: compounds 4 and 1 (each within the scatter of the next); then compounds 3 and 2 (each within the scatter of the next).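

In this assay, a larger fused group at this position does not by itself bring a higher number: the step is a 1.3-fold lower number from compound 1 to compound 4 (0.11 log units; within the scatter), even though the entering group is larger than the 1,5-dimethyl-1H-pyrazol-4-yl group. Among the fused groups, the six-membered non-aromatic ring with 2 hetero atoms stands apart from the two rings with 1 hetero atom, with a 6.6-fold lower number from compound 3 to compound 4 (0.82 log units; beyond the scatter) and a 9.4-fold lower number from compound 2 to compound 4 (0.97 log units; beyond the scatter). No measured finding is available to explain this difference.

From the compounds shown here alone, whether the low number goes with the six-membered ring size or with the added ring nitrogen remains open. Also open, going by these compounds, is how the number would respond to an oxygen in place of that nitrogen, or to an ethyl group in place of the methyl group on it.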